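Swapping the amine on compound 2's carbonyl

The compounds below may be only part of what the source reports. "The series", "measured", "known", "first", "only" and "open" are said of these compounds alone.

Measured in a functional assay on SU-DHL-6 cells (Homo sapiens) for antiproliferative activity, read by MTT assay; on this read-out higher numbers stand for weaker inhibition and lower numbers for stronger inhibition:
- compound 1 `CCOC(=O)CN1CCC[C@H](Nc2ncnc3ccc(-c4cnc(OC)c(C#N)c4)cc23)C1`: 500 nM
- compound 2 `COc1ncc(-c2ccc3ncnc(N[C@H]4CCCN(C(=O)CN(C)C)C4)c3c2)cc1C#N`: 160 nM

Of these two compounds, compound 2 has the lower number, 160 nM, and so the stronger inhibition. Compound 3 `COc1ncc(-c2ccc3ncnc(N[C@H]4CCCN(C(=O)C(C)N)C4)c3c2)cc1C#N` keeps the shared core and alters one group, with 1-aminoethyl in place of (dimethylamino)methyl on a carbonyl carbon.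

For the measured compounds named here, only one measured step bears on this change: a 3.1-fold lower number from compound 1 to compound 2 (0.49 log units; beyond the scatter). That modest step replaced (ethoxycarbonyl)methyl with ((dimethylamino)methyl)carbonyl on an amine nitrogen in a ring. Compound 3 keeps the carbonyl and changes only the group on it, so a smaller step is expected in this assay, with no firm direction. The estimated step is a 1.1-fold higher number from compound 2 to compound 3 (0.05 log units; within the scatter), which would lie within the usual scatter. For compound 3 the expected value is 180 nM, with an estimated range of 70 nM to 450 nM.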

Compound 3, half-maximal inhibitory concentration: 440 nM
Compound 3: middle estimate off by 2.4-fold (0.39 log units), on the low side; low and high end bracket the measured number.
By their numbers in this assay, from the lowest: compound 2; then compounds 3 and 1 (each within the scatter of the next).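

In this assay the change on the carbonyl carbon gives a 2.8-fold higher number from compound 2 to compound 3 (0.44 log units; beyond the scatter) even though the carbonyl itself stays, so the group placed there matters and the carbonyl alone does not carry the gain seen in compound 2. Compound 3 also sits level with compound 1, with a 1.1-fold lower number from compound 1 to compound 3 (0.06 log units; within the scatter) on going from (ethoxycarbonyl)methyl to (1-aminoethyl)carbonyl. The swap brings in 1 hydrogen-bond donor where there were 0, but no measurement here explains the difference in numbers.

Compound 3 differs from compound 2 both in what sits on the amine nitrogen and in the carbon that carries it, and these compounds cannot separate those two changes. Going by these compounds, how a plain aminomethyl group or a longer chain such as 2-(dimethylamino)ethyl would behave on the same carbonyl remains open.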